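Benzyl link in place of phenyl: expected antagonist potency

A few compounds are considered here, and "the series" means these few. Any claim that something is new, unique, unknown or untested is made for them only; others in the source may bear on it.

Compound 3 `COc1cc(COc2cc(N)c(Cl)cc2C(=O)CCCCN2CCCCC2)cc(OC)c1` stands in a functional assay for antagonist activity at 5-hydroxytryptamine receptor 4 (Rattus norvegicus) (a higher number here means a more potent compound, by a factor of ten per unit of this negative logarithm, a lower number a less potent compound), at 8.5, level with compound 2 `COc1ccc(COc2cc(N)c(Cl)cc2C(=O)CCCCN2CCCCC2)cc1OC` at 8.5 and, within the scatter, a number 0.10 log units higher from compound 1 to compound 3 (within the scatter) above compound 1 `COc1ccc(COc2cc(N)c(Cl)cc2C(=O)CCCCN2CCCCC2)cc1`, which gives 8.4 in this assay. The three measured values therefore sit together, and no one of them can be called the most potent.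

The next step goes to compound 4 `COc1ccc(CCOc2cc(N)c(Cl)cc2C(=O)CCCCN2CCCCC2)cc1OC`: 3,4-dimethoxybenzyl in place of 3,5-dimethoxyphenyl on a saturated chain carbon bound to an oxygen on an aromatic ring.

For the measured compounds named here, two measured steps bear on this change. The methoxy pattern part is covered by no change at the digits printed from compound 2 to compound 3 (within the scatter), and the addition of a methoxy by a number 0.10 log units higher from compound 1 to compound 2 (within the scatter); both are within the scatter. Neither measured step covers the benzyl in place of phenyl on the saturated chain carbon bound to the ring oxygen, so that part of the change rests on no data in this series.

In this assay compound 4 is therefore expected to show a number 0.20 log units lower from compound 3 to compound 4 (within the scatter), no step beyond the scatter, with the range widened for the untested link; the estimate for compound 4 is 8.3, between 7.6 and 9.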

Compound 4, negative logarithm of the antagonist equilibrium constant: 6.8
Compound 4: the middle estimate sits 1.50 log units above what was measured; the whole stated range lies above it.
By their numbers in this assay, from the lowest: compound 4; then compounds 1, 2 and 3 (each within the scatter of the next).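

In this assay, the group on the saturated chain carbon bound to an oxygen on an aromatic ring gave no step beyond the scatter among the methoxy patterns of compounds 1 to 3, but 3,4-dimethoxybenzyl in place of 3,4-dimethoxyphenyl gives a large one (a number 1.70 log units lower from compound 2 to compound 4 (beyond the scatter)), with the same methoxy pattern on both sides. The other two steps agree (a number 1.70 log units lower from compound 3 to compound 4 (beyond the scatter); a number 1.60 log units lower from compound 1 to compound 4 (beyond the scatter)), so compound 4 is the least potent of the four, and among these compounds the link matters more than the methoxy pattern. No measurement at hand accounts for the size of this step.

From the compounds shown here alone, whether 3,5-dimethoxybenzyl or an unsubstituted benzyl follows compound 4 remains open. So does the outcome with a longer chain, such as 3-phenylpropyl, or with an amide in the link.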